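Lengthening the hydroxyalkyl chain: little change expected

The source may report more compounds than this note shows. Statements on the series, on what has been measured and on what is new or still open speak of the compounds shown alone.

Compound 2 `Cc1nc([C@H](NC(=O)c2ccc(-c3ccc(Cl)c(F)c3)[nH]2)[C@@H]2CCCCN2)sc1CCO` gives 16800 nM in a toxicity assay on MT2 cells (Homo sapiens) for cytotoxicity, read by XTT assay, with a stated time of 4 days; a lower number here means that less compound is tolerated, a higher number that more compound is tolerated. This is the lowest of the three numbers shown, yet the other two lie within the scatter of it. Compound 1 `Cc1nc([C@@H](NC(=O)c2ccc(-c3ccc(Cl)c(F)c3)[nH]2)[C@@H]2CCCCN2)sc1CCO` gives 16900 nM and compound 3 `Cc1nc([C@H](NC(=O)c2ccc(-c3ccc(Cl)cc3)[nH]2)[C@@H]2CCCCN2)sc1CCO` gives 21000 nM. The step of a 1.0-fold lower number from compound 1 to compound 2 (0.00 log units; within the scatter) goes with the fact that compounds 1 and 2 differ only in the configuration as drawn, and the step of a 1.3-fold higher number from compound 2 to compound 3 (0.10 log units; within the scatter) is also small. Compound 4 `Cc1nc([C@H](NC(=O)c2ccc(-c3ccc(Cl)c(F)c3)[nH]2)[C@@H]2CCCCN2)sc1CCCO` differs from compound 2 by hydroxymethyl in place of hydroxy on a saturated chain carbon, two bonds along the chain from an aromatic carbon. Neither measured step touches this part of the structure, and both stayed within the scatter, so compound 4 is expected to be tolerated to a similar degree, with the step of a 1.0-fold higher number from compound 2 to compound 4 (0.01 log units; within the scatter) expected to fall within the scatter. Compound 4 is estimated at 17000 nM, with a range from 8500 nM to 34000 nM.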

Compound 4, half-maximal cytotoxic concentration: 12600 nM
The estimate for compound 4 lay 1.3-fold (0.13 log units) above the measured number, within the range that was stated.
By their numbers in this assay, from the lowest: compounds 4, 2, 1 and 3 (each within the scatter of the next).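

Going from 2-hydroxyethyl to 3-hydroxypropyl in this assay gives a 1.3-fold lower number from compound 2 to compound 4 (0.12 log units; within the scatter) and is the first change shown at this position. Compound 4 and compound 2 therefore cannot be told apart here, so this chain can be extended by this much without a measurable shift in tolerated concentration. Nothing in the information available bears on the reason for this result. Still open, from the compounds shown here alone, is whether a longer chain, or an amine or a carboxylic acid in place of the hydroxy, would also stay within the scatter.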